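The source may hold more compounds than are shown below. What is called first, only, known or untested is meant among the compounds shown, and "the series" means these compounds.

Measured so far:
- compound 1, `NS(=O)(=O)c1nnc(NCc2nc3cc([N+](=O)[O-])ccc3[nH]2)s1`, 230000 nM
- compound 2, `O=[N+]([O-])c1ccc2[nH]c(CNc3c([N+](=O)[O-])ccc4ncccc34)nc2c1`, 274000 nM
- compound 3, `CCOC(=O)c1c(NCc2nc3ccccc3[nH]2)sc2c1CCCCC2`, 40000 nM

In a functional assay on MCF7 cells (Homo sapiens) for cytotoxicity, read by MTT assay (a lower number here means a stronger inhibitor, a higher number a weaker inhibitor), compound 2 gives 274000 nM, the highest of the three numbers. Its nearest neighbour is compound 1, which in this assay gives 230000 nM, a difference that lies within the usual scatter, so the two cannot be told apart. Compound 3, which in this assay gives 40000 nM, sits furthest away, and that gap lies beyond the scatter.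

Compound 4, `O=[N+]([O-])c1ccc2ncccc2c1NCc1nc2ccccc2[nH]1`, has not yet been measured. It differs from compound 2 in one place: hydrogen in place of nitro on an aromatic carbon. Among the compounds with values here, no measured pair in this set shows the effect of exactly this change, so the expectation rests only on the weak activity seen throughout. The step from compound 2 to compound 4 is expected to be small, a 1.4-fold lower number from compound 2 to compound 4 (0.14 log units; within the scatter), with no clear direction beyond the scatter. Compound 4 is therefore estimated at 200000 nM, in the range 60000 nM to 600000 nM.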

Compound 4, half-maximal inhibitory concentration: 237000 nM
The estimate for compound 4 lay 1.2-fold (0.07 log units) below the measured number; the measured number falls inside the stated range.
By their numbers in this assay, from the lowest: compound 3; then compounds 1, 4 and 2 (each within the scatter of the next).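

In this assay, within the data shown here, hydrogen in place of nitro on this aromatic carbon gives a 1.2-fold lower number from compound 2 to compound 4 (0.06 log units; within the scatter) and so provides the first comparison in this set that isolates a single change. Compound 2 and compound 4 cannot be told apart, which shows that, in this one pair, losing the nitro group and its three heavy atoms from this place leaves the number within the scatter. The data at hand offer no measurement that would account for this result.

On these data alone, it remains open whether an amine, a methoxy group or a carboxylic acid on this same aromatic carbon would move the number beyond the scatter. The pair also leaves open whether this change would have the same outcome on a different core, such as that of compound 3.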